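Chloro to Nitro on the Aryl Hydrazone

This account rests on a few compounds, and the source may have more. Where it says the series, first, only, none or still open, it means among the compounds named here.

Compound 1 `c1ccc(NN=C(c2nc3ccccc3[nH]2)c2nc3ccccc3[nH]2)cc1`: 27900 nM
Compound 2 `Clc1ccc(NN=C(c2nc3ccccc3[nH]2)c2nc3ccccc3[nH]2)cc1`: 112000 nM

In a functional assay on CCRF-CEM cells (Homo sapiens) for cytotoxicity, read by MTT assay, with a stated time of 72 h (a higher number here means a weaker inhibitor, a lower number a stronger inhibitor), compound 2 gives 112000 nM, the higher of the two numbers. Going by the values given here, its only neighbour is compound 1, reached by a 4.0-fold higher number from compound 1 to compound 2 (0.60 log units; beyond the scatter), a modest step beyond the scatter. Compound 3 `O=[N+]([O-])c1ccc(NN=C(c2nc3ccccc3[nH]2)c2nc3ccccc3[nH]2)cc1` differs from compound 2 in nitro in place of chloro on an aromatic carbon. Among the compounds with values here, no measured step covers this exchange; only a 4.0-fold higher number from compound 1 to compound 2 (0.60 log units; beyond the scatter) bears on it, showing that a group at this carbon can shift the number modestly. A step within the scatter, in either direction, is therefore expected. Compound 3 is estimated at 85000 nM, ranging from 20000 nM to 300000 nM. The expected step is a 1.3-fold lower number from compound 2 to compound 3 (0.12 log units; within the scatter).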

Compound 3, half-maximal inhibitory concentration: 140000 nM
Estimate against measurement, compound 3: 1.6-fold (0.22 log units) below; measured number inside the range.
By their numbers in this assay, from the lowest: compound 1; then compounds 2 and 3 (each within the scatter of the next).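

In this assay, nitro in place of chloro gives a 1.3-fold higher number from compound 2 to compound 3 (0.10 log units; within the scatter) and so does not separate the two groups at this carbon. Nitro in place of hydrogen gives a 5.0-fold higher number from compound 1 to compound 3 (0.70 log units; beyond the scatter) as well, so the shift seen with chloro recurs with a second group, and compound 1 keeps the lowest number of the three. Nothing measured here accounts for this. From the compounds shown here alone, whether an amine or a carboxylic acid at this carbon would fall with compound 1 or with compounds 2 and 3 remains open.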